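A few compounds are considered here, and "the series" means these few. Any claim that something is new, unique, unknown or untested is made for them only; others in the source may bear on it.

Compound 2 `Cc1ccc(C(=O)c2c(OCC(=O)Nc3ccc(S(N)(=O)=O)cc3C)ccc3cc(C#N)ccc23)cc1C` stands at the edge of the numbers: in an ADME assay on C8166 cells (Homo sapiens) for cytotoxicity, read by colorimetric assay and MTT assay (on this read-out higher numbers stand for lower toxicity in this test and lower numbers for higher toxicity in this test), compound 2 gives > 379000 nM, which is a limit of this assay rather than a measured number, as noted by the limit of > 379000 nM in this assay, at which 1 of the 2 values shown sits. Compound 1 `Cc1cc(C)cc(C(=O)c2c(OCC(=O)Nc3ccc(S(N)(=O)=O)cc3C)ccc3ccccc23)c1` shares the core, and in this assay compound 1 gives 39100 nM. Compound 3 `Cc1cc(C)cc(C(=O)c2c(OCC(=O)Nc3ccc(S(N)(=O)=O)cc3C)ccc3cc(C#N)ccc23)c1` is reached from compound 2 by 3,5-dimethylphenyl in place of 3,4-dimethylphenyl on a carbonyl carbon. Going by the values given here, no measured pair covers this change, so the step of an at least 1.5-fold lower number from compound 2 to compound 3 (0.18 log units; that floor lies within the scatter) is expected to be modest, likely not beyond the usual scatter. In this assay compound 3 is estimated at 250000 nM, with a range from 60000 nM to 600000 nM.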

Compound 3, half-maximal cytotoxic concentration: 128000 nM
Beside the measured number, compound 3's estimate is 2.0-fold (0.29 log units) above it, within the range that was stated.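

In this assay, 3,5-dimethylphenyl in place of 3,4-dimethylphenyl on a carbonyl carbon gives an at least 2.9-fold lower number from compound 2 to compound 3 (0.47 log units; beyond the scatter), so the placing of the methyl groups on this ring does register in this test. The value of compound 2 is a limit, so that step gives only a floor: the limit of > 379000 nM in this assay, at which 1 of the 3 values shown sits. With 3,5-dimethylphenyl held constant, cyano in place of hydrogen on an aromatic carbon gives a 3.3-fold higher number from compound 1 to compound 3 (0.52 log units; beyond the scatter), a shift toward lower toxicity in this test. Going by these compounds, how an amine or a carboxylic acid at the cyano position would read remains open.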